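Swapping the sulfonamide amine: azetidine to ethylamine

The source may hold more compounds than are shown below. What is called first, only, known or untested is meant among the compounds shown, and "the series" means these compounds.

Measured so far:
Compound 1, `[O-][S+]1CC(Nc2nonc2/C(=N/O)Nc2ccc(F)c(Br)c2)C1`, gives 212 nM in an assay on isolated protein for inhibition of Indoleamine 2,3-dioxygenase 1 (Homo sapiens), read by fluorescence, with a stated time of 60 min; on this read-out lower numbers stand for stronger inhibition and higher numbers for weaker inhibition.
Compound 2, `CN(C)S(=O)(=O)CCNc1nonc1/C(=N/O)Nc1ccc(F)c(Br)c1`, gives 105 nM in this assay.
Compound 3, `O=S(=O)(CCNc1nonc1/C(=N/O)Nc1ccc(F)c(Br)c1)N1CCC1`, gives 191 nM in this assay.

Compound 3 stands second highest of these three numbers. Its nearest neighbour is compound 1, with a 1.1-fold lower number from compound 1 to compound 3 (0.05 log units; within the scatter), and the step of a 1.8-fold higher number from compound 2 to compound 3 (0.26 log units; within the scatter) is also within the scatter. Compound 4, `CCNS(=O)(=O)CCNc1nonc1/C(=N/O)Nc1ccc(F)c(Br)c1`, has not yet been measured. It differs from compound 3 by ethylamino in place of azetidin-1-yl on a sulfonyl sulfur. Going by the values given here, the only measured step at the same position is a 1.8-fold higher number from compound 2 to compound 3 (0.26 log units; within the scatter), which changed the group on the sulfonyl sulfur and stayed within the scatter. The step of a 2.0-fold lower number from compound 1 to compound 2 (0.31 log units; beyond the scatter) was beyond the scatter, but it rebuilt the whole group on the ring nitrogen and does not bear directly on this change. Among the compounds with values here, none of the measured compounds carries a hydrogen-bond donor on the sulfonyl sulfur, so that part is untested. Compound 4 is therefore expected to give 150 nM in this assay, with a range from 60 nM to 400 nM. The expected step is a 1.3-fold lower number from compound 3 to compound 4 (0.10 log units; within the scatter), not beyond the scatter.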

Compound 4, half-maximal inhibitory concentration: 95 nM
Compound 4: middle estimate off by 1.6-fold (0.20 log units), on the high side; low and high end bracket the measured number.
By their numbers in this assay, from the lowest: compounds 4, 2, 3 and 1 (each within the scatter of the next, the first and the last beyond it).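

Ethylamino puts a hydrogen-bond donor on the sulfonyl sulfur for the first time among these compounds, and in this assay neither a 2.0-fold lower number from compound 3 to compound 4 (0.30 log units; within the scatter) nor a 1.1-fold lower number from compound 2 to compound 4 (0.04 log units; within the scatter) lies beyond the scatter, so this donor brings no clear gain or loss. Rebuilding the whole group on the ring nitrogen gives a 2.2-fold lower number from compound 1 to compound 4 (0.35 log units; beyond the scatter), a modest step beyond the scatter, and it matches the earlier step of a 2.0-fold lower number from compound 1 to compound 2 (0.31 log units; beyond the scatter) in direction, so the open-chain sulfonamide holds up with either a donor or none on the sulfonyl sulfur. No measurement shown here explains these numbers.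

Still open, going by these compounds, is how the sulfonyl sulfur would respond to a plain unsubstituted amino group or a larger ring such as piperidin-1-yl. The effect of a longer chain than the 2-(ethylsulfamoyl)ethyl group on the ring nitrogen is also unknown.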